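The compounds below may be only part of what the source reports. "The series", "measured", "known", "first", "only" and "open" are said of these compounds alone.

Among the measured compounds shown here, compound 1 `N/C(=N\NC(=S)N1CCSCC1)c1ccccn1` is one of three compounds measured in a functional assay on HeLa cells (Homo sapiens) for cytotoxicity, read by MTT assay, with a stated time of 72 h (a lower number here means a stronger inhibitor, a higher number a weaker inhibitor), where compound 1 gives 7800 nM. That number is the second highest of the three; the nearest is compound 3 `N/C(=N\NC(=S)N1CCN(c2ccccn2)CC1)c1ccccn1` with 8600 nM, within the scatter, and the furthest is compound 2 `N/C(=N\NC(=S)N1CCN(c2ccccn2)CC1)c1ccc(F)cn1` with 2000 nM. For the measured compounds named here, the only measured step, a 4.3-fold higher number from compound 2 to compound 3 (0.63 log units; beyond the scatter), concerns a change on the aromatic ring and does not touch the thiocarbonyl substituent. Compound 4 `N/C(=N\NC(=S)N1CCCCC1)c1ccccn1` differs from compound 1 by piperidin-1-yl in place of thiomorpholin-4-yl on a thiocarbonyl carbon. Going by the values given here, no measured step bears on this change; compound 1 and compound 3, which differ only at the thiocarbonyl substituent, give values within the scatter, so no step beyond the scatter is expected: a 1.0-fold higher number from compound 1 to compound 4 (0.01 log units; within the scatter). Compound 4 is estimated at 8000 nM, range 3500 nM to 18000 nM.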

Compound 4, half-maximal inhibitory concentration: 3800 nM
Compound 4: the middle estimate sits 2.1-fold (0.32 log units) above what was measured; low and high end bracket the measured number.
By their numbers in this assay, from the lowest: compounds 2 and 4 (each within the scatter of the next); then compounds 1 and 3 (each within the scatter of the next).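

In this assay the substituent on the thiocarbonyl carbon now makes a measurable difference: piperidin-1-yl in place of thiomorpholin-4-yl gives a 2.1-fold lower number from compound 1 to compound 4 (0.31 log units; beyond the scatter). Among the compounds shown here, until now, the only step beyond the scatter came from a change on the aromatic ring. Nothing available explains this step.

Open, going by these compounds, is how morpholin-4-yl or an open-chain dimethylamino group would read on the same thiocarbonyl carbon. Also open, on these data alone, is whether fluoro on the aromatic ring, as in compound 2, would lower the number further when paired with piperidin-1-yl.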